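The compounds below may be only part of what the source reports. "The series", "measured", "known", "first", "only" and "open" are said of these compounds alone.

Compound 2 `CCCN(CCC)C(=O)Cc1c(-c2ccc(OC)cc2)nn2c(CC)cc(CC)nc12` gives 5.57 nM in an assay on C6 cells for displacement of a labelled ligand from Translocator protein (Rattus norvegicus), read by scintillation counting, with a stated time of 2 h (on this read-out lower numbers stand for stronger inhibition and higher numbers for weaker inhibition), the lower of the two numbers in hand; compound 1 `CCc1cc(CC)n2nc(-c3ccc(OC)cc3)c(CC(=O)N(C)C)c2n1` gives 37.6 nM. Within the data shown here, the one measured step is a 6.8-fold lower number from compound 1 to compound 2 (0.83 log units; beyond the scatter), so enlarging the amide nitrogen substituents has so far been rewarded. Compound 3 `CCc1cc(CC)n2nc(-c3ccc(OC)cc3)c(CC(=O)N(C)c3ccccc3)c2n1` carries the difference (methyl(phenyl)amino in place of dipropylamino on a carbonyl carbon), the same difference, cut one bond further out, reading dipropylcarbamoyl to methyl(phenyl)carbamoyl. Among the measured compounds shown here, no measured step covers an aromatic group at this position, and the change is not a simple extension of the chain, so a modest loss against compound 2 is expected rather than a gain. For compound 3 the expectation is a step of a 2.7-fold higher number from compound 2 to compound 3 (0.43 log units; beyond the scatter). The estimate for compound 3 is 15 nM, within 5 nM to 45 nM.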

Compound 3, inhibition constant: 6.44 nM
The estimate for compound 3 lay 2.3-fold (0.37 log units) above the measured number; the measured number falls inside the stated range.
By their numbers in this assay, from the lowest: compounds 2 and 3 (each within the scatter of the next); then compound 1.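

An aromatic ring on the amide nitrogen is accepted at this position: methyl(phenyl)amino in place of dipropylamino gives a 1.2-fold higher number from compound 2 to compound 3 (0.06 log units; within the scatter), so these two amides cannot be told apart in this assay. Phenyl in place of methyl on the amide-type nitrogen gives a 5.8-fold lower number from compound 1 to compound 3 (0.77 log units; beyond the scatter), so the improvement over dimethylamino does not depend on propyl chains alone. Nothing at hand bears on the cause of either step. Open, on these data alone, is how a benzyl group or a cyclic amine such as piperidine on the carbonyl carbon would compare, and whether a chlorine or methoxy group on the phenyl ring would shift the number.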